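The source may hold more compounds than are shown below. What is called first, only, known or untested is meant among the compounds shown, and "the series" means these compounds.

Values in a functional assay on DU-145 cells (Homo sapiens) for antiproliferative activity, read by WST assay, with a stated time of 3 days; a higher number here means a weaker inhibitor, a lower number a stronger inhibitor:
- compound 1 `CCOc1c(-c2cc(OC)c(OC)c(OC)c2)oc2ccccc2c1=O`: 6200 nM
- compound 2 `CCCOc1c(-c2cc(OC)c(OC)c(OC)c2)oc2ccccc2c1=O`: 2800 nM
- compound 3 `COc1cc(-c2oc3ccccc3c(=O)c2OC(C)C)cc(OC)c1OC`: > 50000 nM (a limit, not a number)
- compound 4 `CCCC(C)Oc1c(-c2cc(OC)c(OC)c(OC)c2)oc2ccccc2c1=O`: not yet measured

Compound 3 has no number, only the limit > 50000 nM. This is the limit of > 50000 nM in this assay, at which 1 of the 3 values shown sits. The true starting point of the step is therefore unknown.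

From compound 3 to compound 4, isopropyl becomes 1-methylbutyl (ethyl in place of hydrogen on a saturated chain carbon, two bonds along the chain from an oxygen on an aromatic ring). The branch on the carbon bound to oxygen stays, and the chain grows one carbon further out.

The closest measured change at that place is the straight-chain extension, a 2.2-fold lower number from compound 1 to compound 2 (0.35 log units; beyond the scatter), which is modest. The two branching steps are much larger: an at least 8.0-fold higher number from compound 1 to compound 3 (0.90 log units; beyond the scatter) and an at least 17-fold higher number from compound 2 to compound 3 (1.25 log units; beyond the scatter). Compound 4 retains the branch that goes with the high number in compound 3, so the extension alone is unlikely to recover much.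

At best, a modest step toward a lower number is expected in this assay, and no firm size can be set from a limit. The expected step is an at least 1.6-fold lower number from compound 3 to compound 4 (0.22 log units; that floor lies within the scatter). The estimate for compound 4 is 30000 nM, with an expected range of 8000 nM to 50000 nM.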

Compound 4, half-maximal inhibitory concentration: > 50000 nM
Compound 4 ended at the assay's limit; the forecaster's own chance of this, stated with the estimate: 50%; at least 1.6-fold (0.22 log units) between middle value and limit.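

In this assay compound 4 gives > 50000 nM, which is a limit and not a number. Compound 3 and compound 4 therefore offer no measured difference, and the effect of adding ethyl to the branched group cannot be read: the limit of > 50000 nM in this assay, at which 2 of the 4 values shown sit. The loss relative to the unbranched ethers persists with the longer 1-methylbutyl group, with an at least 17-fold higher number from compound 2 to compound 4 (1.25 log units; beyond the scatter) and an at least 8.0-fold higher number from compound 1 to compound 4 (0.90 log units; beyond the scatter), so both compounds carrying a branch on the carbon bound to the oxygen stand at the limit, and none of the four compounds goes against this.

On these data alone, how far compound 3 and compound 4 lie beyond the limit remains open, as does the size of any effect of the added ethyl. Also open, as far as these compounds go, is whether a longer straight chain such as butyl on the same oxygen would extend a 2.2-fold lower number from compound 1 to compound 2 (0.35 log units; beyond the scatter), and whether a branch placed further out, as in 2-methylpropyl, or an amine at the end of the chain would return a readable value.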